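Lengthening the chain toward the hydroxamic acid

The compounds below may be only part of what the source reports. "The series", "measured", "known", "first", "only" and "open" are said of these compounds alone.

Compound 1, `Cn1cc(-c2ccccc2Oc2ccccc2)c2cc(C(=O)NCCCC(=O)NO)[nH]c2c1=O`, is the weaker of the two compounds measured in an assay on isolated protein for inhibition of protein deacetylase HDAC6 (Homo sapiens), read by fluorescence (a lower number here means a stronger inhibitor, a higher number a weaker inhibitor), where compound 1 gives 144 nM. Compound 2, `Cn1cc(-c2cc(C(C)(C)O)ccc2OC2CC2)c2cc(C(=O)NCCCCCCC(=O)NO)[nH]c2c1=O`, differs from compound 1 in several places at once; in this assay compound 2 gives a much lower number, 5.5 nM, a gap well beyond the usual scatter. Compound 3, `Cn1cc(-c2ccccc2Oc2ccccc2)c2cc(C(=O)NCCCCC(=O)NO)[nH]c2c1=O`, is not yet measured; it differs from compound 1 in only one place: (hydroxycarbamoyl)methyl in place of hydroxycarbamoyl on a saturated chain carbon, three bonds along the chain from an amide-type nitrogen. Because compound 2, with its longer chain, gives 5.5 nM, a longer chain in compound 3 is expected to help, though compound 2 also carries other changes, so the size of the gain is uncertain. A moderate step toward a lower number, a 2.4-fold lower number from compound 1 to compound 3 (0.38 log units; beyond the scatter), is expected. Compound 3 is estimated to give 60 nM in this assay, within a range from 20 nM to 180 nM.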

Compound 3, half-maximal inhibitory concentration: 4 nM
Estimate against measurement, compound 3: 15-fold (1.18 log units) above; measured number outside the range, below it.
By their numbers in this assay, from the lowest: compounds 3 and 2 (each within the scatter of the next); then compound 1.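

In this assay, within the data shown here, the single change of (hydroxycarbamoyl)methyl in place of hydroxycarbamoyl gives a 36-fold lower number from compound 1 to compound 3 (1.56 log units; beyond the scatter) and nothing else in the structure differs. This shows that the number is highly sensitive to chain length at this position, on a saturated chain carbon three bonds along the chain from an amide-type nitrogen, which the comparison of compound 1 with compound 2 could not show, as those two differ in several places at once. The compounds shown offer no measured explanation for the size of this step.

As far as these compounds go, whether a longer chain on the core of compound 3, such as 4-(hydroxycarbamoyl)butyl, would lower the number further or raise it remains open. Also open, from the compounds shown here alone, is whether a chain with an amine or an ether oxygen inside it would keep the number as low.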